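Half-life of an amide series: from compound 2 to compound 3

This account rests on a few compounds, and the source may have more. Where it says the series, first, only, none or still open, it means among the compounds named here.

Measured in an ADME assay on microsomes from liver (Mus musculus) for metabolic stability, read by LC-MS, using NADPH, with a stated time of 60 min, tested at 1 uM; on this read-out lower numbers stand for a shorter-lived compound and higher numbers for a longer-lived compound:
- Compound 1 `O=C(O)C1CN(C(=O)CC2Cc3ccc(-c4cc(F)cc(OC(F)F)c4)cc3N2S(=O)(=O)c2cccc(C(F)(F)F)c2)C1`: 1.1 h
- Compound 2 `O=C(CC1Cc2ccc(-c3cc(F)cc(OC(F)F)c3)cc2N1S(=O)(=O)c1cccc(C(F)(F)F)c1)N1CCC(O)CC1`: 0.0117 h

Of the two measured compounds, compound 2 has the lower number, at 0.0117 h, while compound 1 gives 1.1 h. Compound 3 `O=C(CC1Cc2ccc(-c3cc(F)cc(OC(F)F)c3)cc2N1S(=O)(=O)c1cccc(C(F)(F)F)c1)N1CCS(=O)(=O)CC1` has not yet been measured in this assay. It carries 1,1-dioxothiomorpholin-4-yl in place of 4-hydroxypiperidin-1-yl on a carbonyl carbon.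

Within the data shown here, no measured step makes this exact change. The only one available, a 94-fold lower number from compound 1 to compound 2 (1.97 log units; beyond the scatter), is large and beyond the scatter, but it involves 3-carboxyazetidin-1-yl, a group that compound 3 lacks. Its size is therefore not expected to carry over. Both groups in the new change are six-membered non-aromatic rings with no net charge, so compound 3 is expected to stay near compound 2 rather than approach compound 1. The expected step is a 2.6-fold higher number from compound 2 to compound 3 (0.41 log units; beyond the scatter), a modest rise that remains uncertain. For compound 3 the estimated half-life is 0.03 h, with an expected range of 0.01 h to 0.15 h.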

Compound 3, half-life: 0.0333 h
For compound 3 the middle estimate is 1.1-fold (0.05 log units) below the measured one; low and high end bracket the measured number.
By their numbers in this assay, from the lowest: compound 2; then compound 3; then compound 1.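

In this assay, the position on the carbonyl carbon responds even when one six-membered non-aromatic ring with no net charge replaces another: 1,1-dioxothiomorpholin-4-yl in place of 4-hydroxypiperidin-1-yl gives a 2.8-fold higher number from compound 2 to compound 3 (0.45 log units; beyond the scatter). The step is modest, however, and 1,1-dioxothiomorpholin-4-yl in place of 3-carboxyazetidin-1-yl still gives a 33-fold lower number from compound 1 to compound 3 (1.52 log units; beyond the scatter), so the large gap to compound 1 remains with either six-membered ring in this place. Nothing available explains why the half-life moves as it does with either change.

The compounds leave open whether the longer half-life of compound 1 goes with the carboxylic acid or with the smaller azetidine ring, as compound 1 differs from compound 2 and compound 3 in both at once. A carboxylic acid carried on a piperidine ring, or an azetidine amide with a hydroxyl group in place of the carboxylic acid, would separate these two features, while an amine such as a piperazine ring in this place remains untested ground among the compounds shown.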